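Replacing a fluorophenyl with a difluorobenzyloxy group

A few compounds are considered here, and "the series" means these few. Any claim that something is new, unique, unknown or untested is made for them only; others in the source may bear on it.

Of the compounds shown here, two of the shared core have been measured in an assay on CHO cells for positive allosteric modulation of metabotropic glutamate receptor 2 (Homo sapiens), read by scintillation counting, with a stated time of 30 min; on this read-out lower numbers stand for an effect already at smaller amounts and higher numbers for an effect only at larger amounts of compound. Compound 1 `FC(F)(F)c1c(CN2CCC(c3ccccc3)CC2)ccn2c(CC3CC3)nnc12` gives 21 nM. For the measured compounds named here, compound 2 `Fc1ccccc1C1CCN(Cc2ccn3c(CC4CC4)nnc3c2C(F)(F)F)CC1` gives 15 nM; the only recorded step, a 1.4-fold lower number from compound 1 to compound 2 (0.15 log units; within the scatter), is within the scatter, so compound 2 stands at the lower of two numbers that cannot be told apart.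

Compound 3 `Fc1ccc(COC2CCN(Cc3ccn4c(CC5CC5)nnc4c3C(F)(F)F)CC2)c(F)c1` differs from compound 2 as follows: (2,4-difluorobenzyl)oxy in place of 2-fluorophenyl on a saturated ring carbon. Going by the values given here, none of the measured steps bears on this change: the one recorded step concerns a fluorine on an aromatic ring, not a replacement on the saturated ring. Among the compounds with values here, because compound 2 gives 15 nM and no comparable step is known, the direction of the change can only be guessed, and a wide range is needed. Compound 3 is expected to give 30 nM in this assay, between 6 nM and 150 nM, which means an estimated step of a 2.0-fold higher number from compound 2 to compound 3 (0.30 log units; within the scatter).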

Compound 3, half-maximal effective concentration in the metabotropic glutamate receptor 2 assay: 57 nM
The estimate for compound 3 lay 1.9-fold (0.28 log units) below the measured number; measured number inside the range.
By their numbers in the metabotropic glutamate receptor 2 assay, from the lowest: compounds 2 and 1 (each within the scatter of the next); then compound 3.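

In the metabotropic glutamate receptor 2 assay, the saturated ring carbon three ring bonds from the ring nitrogen turns out to respond to a change of group: (2,4-difluorobenzyl)oxy in place of 2-fluorophenyl gives a 3.8-fold higher number from compound 2 to compound 3 (0.58 log units; beyond the scatter). In the metabotropic glutamate receptor 2 assay, the same group in place of phenyl gives a 2.7-fold higher number from compound 1 to compound 3 (0.43 log units; beyond the scatter), so both steps go the same way and, unlike the earlier fluorine step, both lie beyond the scatter. In a physicochemical assay for solubility, read by HPLC, measured as kinetic solubility, at pH 4 (a lower number here means a less soluble compound, a higher number a more soluble compound), compound 2 gives > 100000 nM, which is a limit of the assay and not a number. In the physicochemical assay, compound 3 gives > 100000 nM, which is also a limit of the assay and not a number. In the physicochemical assay, the step from compound 2 to compound 3 cannot be read, and what stands there is a limit, not a number: the limit of > 100000 nM in the physicochemical assay, at which 2 of the 2 values shown sit.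

From the compounds shown here alone, the entering group brings an oxygen, one more carbon and a second fluorine all at once, so it stays open which of these goes with the higher number. Going by these compounds, how an amine or a carboxylic acid on this ring carbon would read also stays open.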